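This account rests on a few compounds, and the source may have more. Where it says the series, first, only, none or still open, it means among the compounds named here.

Measured compounds:
compound 1 `O=c1[nH]nc2n(c1=O)CCN2c1ccccc1` with 0%
compound 2 `Cc1ccc(N2CCn3c2n[nH]c(=O)c3=O)cc1` with 22%

In a functional assay on T47D cells (Homo sapiens) for cytotoxicity, with a stated time of 72 h, tested at 50 ug/mL (on this read-out higher numbers stand for a stronger effect at the one concentration tested and lower numbers for a weaker effect), compound 1 stands at the bottom of the two numbers: compound 1 gives 0%, and its nearest neighbour, compound 2, gives 22%, a gap beyond the scatter. Compound 3 `O=c1[nH]nc2n(c1=O)CCN2c1cccc(Cl)c1` has not been measured. It differs from compound 1 by chloro in place of hydrogen on an aromatic carbon. Among the measured compounds shown here, the only measured step that bears on this is a number 22 percentage points higher from compound 1 to compound 2 (beyond the scatter), which involved methyl in place of hydrogen on an aromatic carbon; no measured step shows a chloro group, nor a group at this place of the ring. That single step is modest, so a modest rise is expected for compound 3, with wide uncertainty because compound 1 sits at 0%. The estimated step is a number 15 percentage points higher from compound 1 to compound 3 (beyond the scatter). Compound 3 is therefore expected to give about 15%, between 0% and 35%.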

Compound 3, a percentage reported as inhibition, at one concentration (the size of the read-out at that concentration, not a potency): 0%
For compound 3 the middle estimate is 15 percentage points above the measured one, within the range that was stated.
By their numbers in this assay, from the lowest: compounds 1 and 3 (each within the scatter of the next); then compound 2.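

In this assay chloro in place of hydrogen, meta to a large group on the six-membered aromatic ring, gives no change at the digits printed from compound 1 to compound 3 (within the scatter) and so leaves the read-out where the core of compound 1 has it. A new group on this ring therefore does not by itself raise the number. Methyl in compound 2 goes against any such pattern, with a number 22 percentage points higher from compound 1 to compound 2 (beyond the scatter) in this assay while chloro at this place brings no such step.

The compounds shown leave open whether an amine, a carboxylic acid or a methoxy group at this place would move the number, and whether methyl here would match the step seen for compound 2. Nothing measured here accounts for the absence of a step with chloro.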